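Swapping the ring on the aromatic nitrogen

The source may report more compounds than this note shows. Statements on the series, on what has been measured and on what is new or still open speak of the compounds shown alone.

Among the measured compounds shown here, in a functional assay on a cell-free system (Platelet, plasma, Homo sapiens) for inhibition, read by turbidimetry, with a stated time of 3 min (on this read-out lower numbers stand for stronger inhibition and higher numbers for weaker inhibition), compound 2 (`O=C(c1cc(-c2ccc(Cl)cc2)n(-c2ccc(=O)[nH]n2)n1)N1CCCCC1`) gives 2090 nM and so holds the higher of the two numbers measured so far. Compound 1 (`COc1ccc(-n2nc(C(=O)N3CCCCC3)cc2-c2ccc(Cl)cc2)nn1`) stands at 41 nM on the same scale. Compound 3 (`COc1ccc(-n2nc(C(=O)N3CCCCC3)cc2-c2ccc(Cl)cc2)cc1`) differs from compound 2 in one place (a group of 8 heavy atoms (7 carbon, 1 oxygen; one six-membered aromatic ring of carbon only) in place of a group of 7 heavy atoms (4 carbon, 2 nitrogen, 1 oxygen; one six-membered aromatic ring with 2 hetero atoms), on an aromatic nitrogen) and carries 4-methoxyphenyl on that nitrogen. For the measured compounds named here, the one measured step that bears on this is a 51-fold higher number from compound 1 to compound 2 (1.71 log units; beyond the scatter) and it is large, so the group at this place can move the number a long way. Compound 1 also has a methoxy group on a six-membered aromatic ring there, which makes its 41 nM the best guide available. The step expected in this assay is a 35-fold lower number from compound 2 to compound 3 (1.54 log units; beyond the scatter) and it would be large, towards stronger inhibition. Compound 3 is estimated at 60 nM within an expected range of 15 nM to 250 nM in this measurement.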

Compound 3, half-maximal inhibitory concentration: 7.9 nM
Beside the measured number, compound 3's estimate is 7.6-fold (0.88 log units) above it; measured number outside the range, below it.
By their numbers in this assay, from the lowest: compound 3; then compound 1; then compound 2.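

In this assay the step of a 260-fold lower number from compound 2 to compound 3 (2.42 log units; beyond the scatter) spans a wider range than the earlier pair showed, so the group on this aromatic nitrogen can move the number even further than it first appeared. With the methoxy group kept and only the ring changed, the step of a 5.2-fold lower number from compound 1 to compound 3 (0.72 log units; beyond the scatter) shows that the two ring nitrogens of 6-methoxypyridazin-3-yl are not needed for a low number, as the ring of carbon only gives a lower one. Nothing measured here explains this difference between the two rings.

The compounds shown leave open whether the methoxy group itself matters, as none carries a plain phenyl ring on this nitrogen. From the compounds shown here alone, how an amine, a carboxylic acid or a longer chain such as ethoxy on that ring would shift the number also remains open.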